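Methoxy in place of hydrogen on the shared core

This account rests on a few compounds, and the source may have more. Where it says the series, first, only, none or still open, it means among the compounds named here.

Among the measured compounds shown here, compound 1 `CCOC(=O)C(=O)Nc1cccccc1=O` gives 79% in a functional assay on the whole organism (strain Sprague-Dawley CD) for inhibition, with Rattus norvegicus as the target, read by paw edema, at a dose of 30 mg/kg by the oral route (a lower number here means a weaker effect, a higher number a stronger effect of the compound at the dose given), the higher of the two numbers measured so far. For the measured compounds named here, compound 2 `CCOC(=O)C(=O)Nc1ccccc(NC)c1=O` gives 0% in this assay, and the single measured step, a number 79 percentage points lower from compound 1 to compound 2 (beyond the scatter), is a large one. Compound 3 `CCOC(=O)C(=O)Nc1ccc(OC)ccc1=O` is not yet measured. It differs from compound 1 by methoxy in place of hydrogen on an aromatic carbon, the methoxy entering on an aromatic carbon of the seven-membered aromatic ring of carbon only, three ring bonds from the ring atom that bears a group of 8 heavy atoms. The step from compound 1 to compound 2 is the only one that bears on this change, and it concerns a different group at a different place, so it transfers only loosely. A loss in this assay is expected, though smaller than that seen for compound 2, with compound 3 estimated at 40% (range 5% to 80%), a step of a number 39 percentage points lower from compound 1 to compound 3 (beyond the scatter) being expected.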

Compound 3, a percentage reported as inhibition, in the whole organism at one dose (the size of the read-out at that dose, not a potency): 31%
Compound 3: middle estimate off by 9 percentage points, on the high side, within the range that was stated.
By their numbers in this assay, from the lowest: compound 2; then compound 3; then compound 1.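

In this assay, methoxy in place of hydrogen, three ring bonds from the ring atom that bears a group of 8 heavy atoms, comes at a clear cost, with a number 48 percentage points lower from compound 1 to compound 3 (beyond the scatter) as a large step. The effect is reduced but not lost, as compound 3 still gives 31% at the dose given, so this aromatic carbon carries methoxy with part of the oral anti-edema effect retained. Nothing measured here accounts for the loss.

The compounds shown leave open whether the loss belongs to methoxy itself or to any group at this carbon; a hydroxy group, a fluorine atom or a carboxylic acid there would help to separate the two. On these data alone, how methoxy behaves on the other carbons of the ring also remains open.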